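Replacing benzoyl with cyano on compound 2

The compounds below may be only part of what the source reports. "The series", "measured", "known", "first", "only" and "open" are said of these compounds alone.

Compound 1 `C=C[C@@](C)(/C=C/c1ccc(O)c(C=O)c1)CCC=C(C)C`: > 49000 nM (a limit)
Compound 2 `C=C[C@@](C)(/C=C/c1ccc(O)c(/C=C/C(=O)c2ccccc2)c1)CCC=C(C)C`: > 49000 nM (a limit)

Both compounds were tested in a functional assay on Jurkat cells (Homo sapiens) for cytotoxicity, with a stated time of 72 h; a higher number here means that more compound is needed for the effect, a lower number that less compound is needed. Compound 2 stands at > 49000 nM, which is a limit of the assay and not a number. Compound 1 gives > 49000 nM, also a limit. Neither compound therefore provides an exact value to compare.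

Compound 3 `C=C[C@@](C)(/C=C/c1ccc(O)c(/C=C/C#N)c1)CCC=C(C)C` has not yet been measured. It differs from compound 2 by this change: cyano in place of benzoyl on a double-bonded chain carbon bound to a double-bonded chain carbon. In words, it has cyano in place of benzoyl on a double-bonded chain carbon bound to a double-bonded chain carbon.

No step beyond the scatter is expected in this assay, an expectation that rests only on (the limit of > 49000 nM in this assay, at which 2 of the 2 values shown sit). The estimated change is a number no higher from compound 2 to compound 3 (the limit leaves the size open). Compound 3 is expected at about 49000 nM. Its estimated range runs from 20000 nM to 100000 nM.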

Compound 3, half-maximal effective concentration: > 49000 nM
Compound 3 was reported as a limit (the forecaster's own chance of this, stated with the estimate: 75%); the middle value sits exactly at the limit.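

In this assay compound 3 gives > 49000 nM, which is a limit of the assay and not a number. The steps from compound 1 and from compound 2 to compound 3 therefore cannot be read: the limit of > 49000 nM in this assay, at which 3 of the 3 values shown sit.

Going by these compounds, what stays open is whether cyano in place of benzoyl changes the concentration needed for the effect at all.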